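A few compounds are considered here, and "the series" means these few. Any claim that something is new, unique, unknown or untested is made for them only; others in the source may bear on it.

Measured compounds:
compound 1 `CNc1ncc2c(-c3ccc(OC)cc3)nn(CC3OCCO3)c2n1` — 1200 nM
compound 2 `CNc1ncc2c(-c3ccc(N4CCNCC4)nc3)nn(Cc3cn(-c4ccsc4C(=O)OC)nn3)c2n1` — 430 nM
compound 3 `CNc1ncc2c(-c3ccc(N4CCN(C)CC4)nc3)nn(Cc3cn(Cc4ccccc4)nn3)c2n1` — 900 nM

In an assay for inhibition of proto-oncogene tyrosine-protein kinase receptor Ret (Homo sapiens), read by 33P incorporation, in the presence of a further agent that is not named here (a lower number here means a stronger inhibitor, a higher number a weaker inhibitor), compound 3 gives 900 nM, the second highest of the three numbers. Compound 1 gives 1200 nM, and this value and that of compound 3 lie within the scatter of each other, so nothing separates them. Compound 2 gives 430 nM, a lower number than that of compound 3, and this gap is beyond the scatter.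

Compound 4 `CNc1ncc2c(-c3ccc(N4CCN(C(=O)C(C)(C)C)CC4)nc3)nn(Cc3cn(Cc4ccccc4)nn3)c2n1` has not yet been measured in this assay. It differs from compound 3 in one place: (tert-butyl)carbonyl in place of methyl on an amine nitrogen in a ring. Within the data shown here, no pair of measured compounds differs by this change alone, so there is no measured step to lean on. Among the measured compounds shown here, only three compounds are in hand, and they differ from one another in several places at once. The expectation is therefore a step of modest size, with no clear direction, from compound 3 to compound 4, as no change at the digits printed from compound 3 to compound 4 (within the scatter) expresses. Compound 4 is estimated to give 900 nM in this assay, expected between 300 nM and 2700 nM.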

Compound 4, half-maximal inhibitory concentration: 4000 nM
Compound 4: the middle estimate sits 4.4-fold (0.65 log units) below what was measured; the measured number lies above the stated range.
By their numbers in this assay, from the lowest: compound 2; then compounds 3 and 1 (each within the scatter of the next); then compound 4.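

In this assay, among these compounds, replacing 4-methylpiperazin-1-yl with 4-((tert-butyl)carbonyl)piperazin-1-yl gives a 4.4-fold higher number from compound 3 to compound 4 (0.65 log units; beyond the scatter), the first comparison here in which only one place differs, and it shows that the group on this ring nitrogen affects inhibition. The change brings several differences at once: six heavy atoms replace one, and a carbonyl adds a hydrogen-bond acceptor, so this single step cannot show which difference matters. No measurement at hand explains the loss of inhibition.

The compounds shown leave open whether acetyl on the same nitrogen, which keeps the carbonyl with fewer carbons, or neopentyl, which keeps five carbons without the carbonyl, would fall nearer compound 3 or compound 4. They also leave open whether the same change would have a similar effect with the other group of compound 2 on the triazole.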